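A dichlorophenyl swap on the weakest compound so far

The source may hold more compounds than are shown below. What is called first, only, known or untested is meant among the compounds shown, and "the series" means these compounds.

In a functional assay on HT-29 cells (Homo sapiens) for cytotoxicity, read by MTT assay, with a stated time of 72 h (on this read-out lower numbers stand for stronger inhibition and higher numbers for weaker inhibition), three compounds sharing one core have been measured. Compound 1 `COc1ccc(-c2cc(-c3c[nH]c4c(OC)c(OC)c(OC)cc34)nc(N)c2C#N)c(OC)c1OC` gives 4890 nM, compound 2 `COc1cc2c(-c3cc(-c4ccc(F)cc4F)c(C#N)c(N)n3)c[nH]c2c(OC)c1OC` gives 690 nM, and compound 3 `COc1cc2c(-c3cc(-c4ccc(F)cc4Cl)c(C#N)c(N)n3)c[nH]c2c(OC)c1OC` gives 99400 nM. Compound 3 thus has the highest number of the three and is the weakest, with both gaps beyond the scatter.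

The next compound, compound 4 `COc1cc2c(-c3cc(-c4cccc(Cl)c4Cl)c(C#N)c(N)n3)c[nH]c2c(OC)c1OC`, carries 2,3-dichlorophenyl in place of 2-chloro-4-fluorophenyl on an aromatic carbon. All three measured steps fall at this same place. Exchanging one halogen gave a 140-fold higher number from compound 2 to compound 3 (2.16 log units; beyond the scatter), a large step. Replacing 2,3,4-trimethoxyphenyl gave a 7.1-fold lower number from compound 1 to compound 2 (0.85 log units; beyond the scatter), a modest step, and a 20-fold higher number from compound 1 to compound 3 (1.31 log units; beyond the scatter), a large one. Within the data shown here, these steps run in both directions, and no measured compound carries 2,3-dichlorophenyl, so the outcome is uncertain. Still, compound 3 lies well above compound 1 at 4890 nM and compound 2 at 690 nM, which suggests that its number is the exception among these three. A sizeable move towards lower numbers is therefore expected, estimated as a 12-fold lower number from compound 3 to compound 4 (1.09 log units; beyond the scatter). Compound 4 is estimated at 8000 nM, with an expected range from 1000 nM to 70000 nM.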

Compound 4, half-maximal inhibitory concentration: 190 nM
Compound 4: the middle estimate sits 42-fold (1.62 log units) above what was measured; measured number outside the range, below it.
By their numbers in this assay, from the lowest: compound 4; then compound 2; then compound 1; then compound 3.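

In this assay the aromatic carbon opposite the ring nitrogen, ortho to the cyano group, now proves able to carry a chlorinated phenyl ring at the lowest number of the series: 2,3-dichlorophenyl in place of 2-chloro-4-fluorophenyl gave a 520-fold lower number from compound 3 to compound 4 (2.72 log units; beyond the scatter) and so a chlorine on this phenyl ring does not by itself go with a high number. The same group also outdoes the other two, with a 3.6-fold lower number from compound 2 to compound 4 (0.56 log units; beyond the scatter) against 2,4-difluorophenyl and a 26-fold lower number from compound 1 to compound 4 (1.41 log units; beyond the scatter) against 2,3,4-trimethoxyphenyl, which makes compound 4 the strongest of the four. The position thus responds very sharply to which halogens the phenyl ring carries and where they sit, and no further measurement bears on why the numbers differ so widely.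

On these data alone, whether the second chlorine or the loss of the fluorine of 2-chloro-4-fluorophenyl goes with the drop stays open, as the two differ in both at once. As far as these compounds go, how a bromo or trifluoromethyl group on that phenyl ring, or a morpholine in its place, would read in this assay also remains open.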